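The source may report more compounds than this note shows. Statements on the series, on what has been measured and on what is new or still open speak of the compounds shown alone.

Measured so far:
- compound 1 `CCCCCOC(=O)N1CCN(C(=O)[C@H](CCC(=O)O)NC(=O)c2cc(N3CCC(C(=O)N(CC)CC)CC3)nc(-c3ccccc3)n2)CC1`: 38%
- compound 2 `CCCCCOC(=O)N1CCN(C(=O)[C@H](CCC(=O)O)NC(=O)c2cc(N3CCC(C(=O)N4CCCC4)CC3)nc(-c3ccccc3)n2)CC1`: 13%

Compound 2 holds the lower of the two numbers in an in vivo ADME assay on the whole organism (strain Sprague-Dawley) for pharmacokinetics, with Rattus norvegicus as the target, at a dose of 5 mg/kg by the oral route; on this read-out higher numbers stand for higher oral bioavailability and lower numbers for lower oral bioavailability; compound 1 is the nearest neighbour, and the step of a number 25 percentage points lower from compound 1 to compound 2 (beyond the scatter) lies beyond the scatter. Compound 3 `CCCCCOC(=O)N1CCN(C(=O)[C@H](CCC(=O)O)NC(=O)c2cc(N3CCC(CNC)CC3)nc(-c3ccccc3)n2)CC1` differs from compound 2 by (methylamino)methyl in place of (pyrrolidin-1-yl)carbonyl on a saturated ring carbon. For the measured compounds named here, no measured step covers this exchange: the only step known, from an amide with diethylamino to one with pyrrolidin-1-yl, keeps a carbonyl that is lost here, so it bears on the step to compound 3 only as a sign that this position moves oral bioavailability by a modest amount. With the starting point already low, the expected step of a number 3 percentage points lower from compound 2 to compound 3 (within the scatter) is small and its direction uncertain. Compound 3 is therefore estimated at 10% in this assay, with a range from 2% to 30%.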

Compound 3, oral bioavailability: 2%
For compound 3 the middle estimate is 8 percentage points above the measured one; measured number inside the range.
By their numbers in this assay, from the lowest: compound 3; then compound 2; then compound 1.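

In this assay, replacing either amide on the saturated ring carbon with (methylamino)methyl lowers the number: a number 11 percentage points lower from compound 2 to compound 3 (beyond the scatter), and a number 36 percentage points lower from compound 1 to compound 3 (beyond the scatter). For the compounds shown here, the earlier pair varied only the amine part of a retained carbonyl, whereas this change removes the carbonyl and brings in a hydrogen-bond donor, and compound 3, the one compound of the three without an amide at this position, stands lowest. No measurement at hand explains this drop.

The contributions of the lost carbonyl, the added donor and the smaller group remain inseparable. A (dimethylamino)methyl group, which has no hydrogen on its nitrogen, and a methylcarbamoyl group, which keeps both the carbonyl and an amide hydrogen, would bear directly on that question.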